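Working notes: one group exchanged on compound 3

The source may hold more compounds than are shown below. What is called first, only, known or untested is meant among the compounds shown, and "the series" means these compounds.

compound 1 `O=C(N/N=C/c1ccc(F)cc1)Nc1cc2c(Nc3ccc(F)c(Cl)c3)ncnc2cc1O[C@H]1CCOC1` gives "not active" (no number reported)
compound 2 `O=C(N/N=C/c1ccc([N+](=O)[O-])cc1)Nc1cc2c(Nc3ccc(F)c(Cl)c3)ncnc2cc1O[C@H]1CCOC1` gives 33500 nM
compound 3 `COc1cc2ncnc(Nc3ccc(F)c(Cl)c3)c2cc1NC(=O)N/N=C/c1ccc(F)cc1` gives 36500 nM

All three results come from a functional assay on PC-3 cells (Homo sapiens) for cytotoxicity, read by MTT assay, with a stated time of 72 h (on this read-out lower numbers stand for stronger inhibition and higher numbers for weaker inhibition), and form a small set. For the measured compounds named here, compound 1 gives no number, so only two values can be compared. In this assay compound 3 gives 36500 nM and stands within the scatter of its nearest neighbour, compound 2 at 33500 nM, so neither can be ranked above the other.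

The next structure is compound 4 `COc1cc2ncnc(Nc3ccc(F)c(Cl)c3)c2cc1NC(=O)N/N=C/c1cc(OC)c(OC)c(OC)c1`, still unmeasured. It carries 3,4,5-trimethoxyphenyl in place of 4-fluorophenyl on a carbon with a double bond to nitrogen and is otherwise the same as compound 3.

Going by the values given here, no measured pair gives a numerical step for a change at this place, so the expectation has little direct support. It rests on compound 3 at 36500 nM, the closest measured structure. A report without a number also remains possible, as compound 1 shows with "not active" (no number reported). In this assay no step beyond the scatter is expected, and the estimated change is a 1.3-fold lower number from compound 3 to compound 4 (0.12 log units; within the scatter), with no clear direction. Compound 4 is expected at 28000 nM, with an estimated range from 10000 nM to 75000 nM.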

Compound 4, half-maximal inhibitory concentration: 36500 nM
Estimate against measurement, compound 4: 1.3-fold (0.12 log units) below; measured number inside the range.
By their numbers in this assay, from the lowest: compounds 2, 3 and 4 (each within the scatter of the next).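

Within this assay, 3,4,5-trimethoxyphenyl in place of 4-fluorophenyl on a carbon with a double bond to nitrogen gives no change at the digits printed from compound 3 to compound 4 (within the scatter), and this is the first step that can be read at this place. The change is not a small one on paper: the entering group has more heavy atoms than the leaving group and carries hydrogen-bond acceptors where the leaving group has none, yet the read-out does not register the exchange. The series offers no measurement that could account for this flat result.

This single step does not show whether the place is insensitive in general, since both groups are substituted phenyl rings and an aminomethyl group or a carboxylic acid on the ring, or a straight alkyl chain in place of the ring, could behave differently. Also open, on these data alone, is whether the same exchange would give a similar result on the core of compound 1, which carries an oxygen-linked saturated ring in place of the methoxy group, and whether any group at this place can move the number beyond the scatter.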